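Swapping Azidomethyl for Vinyl on the Amide Carbonyl

The compounds below may be only part of what the source reports. "The series", "measured", "known", "first", "only" and "open" are said of these compounds alone.

Compound 1 `CCC(=O)N(Cc1ccc(OC)c(O)c1)c1cc(OC)c(OC)c(OC)c1` gives 98 nM in a functional assay on KYSE-450 cells (Homo sapiens) for inhibition, read by MTT assay, with a stated time of 48 h; a higher number here means a weaker inhibitor, a lower number a stronger inhibitor.
Compound 2 `COc1ccc(CN(C(=O)CN=[N+]=[N-])c2cc(OC)c(OC)c(OC)c2)cc1O` gives 160 nM in this assay.

Of these two numbers compound 2 holds the higher one, and its nearest neighbour is compound 1, separated only by a 1.6-fold higher number from compound 1 to compound 2 (0.21 log units; within the scatter). Compound 3 `C=CC(=O)N(Cc1ccc(OC)c(O)c1)c1cc(OC)c(OC)c(OC)c1` differs from compound 2 by vinyl in place of azidomethyl on a carbonyl carbon. Going by the values given here, the single measured step that touches this same carbonyl substituent, from compound 1 to compound 2, stayed within the scatter, so no step beyond the scatter is expected here either. For compound 3 the expected value in this assay is 110 nM, in a range from 45 nM to 270 nM. The step this estimate implies is a 1.5-fold lower number from compound 2 to compound 3 (0.16 log units; within the scatter).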

Compound 3, half-maximal inhibitory concentration: 160 nM
Compound 3: middle estimate off by 1.5-fold (0.16 log units), on the low side; the range from low to high includes it.
By their numbers in this assay, from the lowest: compounds 1, 2 and 3 (each within the scatter of the next).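

In this assay vinyl in place of azidomethyl gives no change at the digits printed from compound 2 to compound 3 (within the scatter) and vinyl in place of ethyl gives a 1.6-fold higher number from compound 1 to compound 3 (0.21 log units; within the scatter) on the same carbonyl carbon. Three different groups at this place, ethyl, azidomethyl and vinyl, now lie within the scatter of one another, where before only two could be compared. Nothing at hand explains why these numbers sit so close.

The compounds shown leave open what a longer chain, an amine or a carboxylic acid on this carbonyl carbon would give. They also leave open whether this closeness would hold in other cell lines.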